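The compounds below may be only part of what the source reports. "The series", "measured", "known", "first", "only" and "open" are said of these compounds alone.

Measured so far in a functional assay on HepG2 cells (Homo sapiens) for inhibition, read by MTT assay, with a stated time of 120 h; a higher number here means a weaker inhibitor, a lower number a stronger inhibitor: compound 1 `CC(NC(=O)C#Cc1ccc(NC(=O)Nc2cc(C(F)(F)F)ccc2Cl)cc1)c1ccccc1` gives 19000 nM; compound 2 `CC(NC(=O)/C=C/c1ccc(NC(=O)Nc2ccc(Cl)c(C(F)(F)F)c2)cc1)c1ccccc1` gives 12200 nM; compound 3 `CC(NC(=O)C#Cc1ccc(NC(=O)Nc2ccc(Cl)c(C(F)(F)F)c2)cc1)c1ccccc1` gives 20500 nM.

Compound 4 `CC(NC(=O)/C=C/c1ccc(NC(=O)Nc2cc(C(F)(F)F)ccc2Cl)cc1)c1ccccc1` has not yet been measured. Compound 2 and compound 3 differ in their cores; that difference is not broken down here, and their two values in this assay lie within the scatter of each other. From compound 3 to compound 1 the change is 2-chloro-5-(trifluoromethyl)phenyl in place of 4-chloro-3-(trifluoromethyl)phenyl on an amide-type nitrogen, and the step was a 1.1-fold lower number from compound 3 to compound 1 (0.03 log units; within the scatter). The same change, at the same place, is made from compound 2 to compound 4: 2-chloro-5-(trifluoromethyl)phenyl in place of 4-chloro-3-(trifluoromethyl)phenyl on an amide-type nitrogen. Within the data shown here, because the one measured instance of this change gave a 1.1-fold lower number from compound 3 to compound 1 (0.03 log units; within the scatter), compound 4 is expected to move by only a 1.1-fold lower number from compound 2 to compound 4 (0.03 log units; within the scatter). The estimate for compound 4 in this assay is therefore 11500 nM, expected to fall between 5000 nM and 28000 nM.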

Compound 4, half-maximal inhibitory concentration: 35900 nM
Compound 4: the middle estimate sits 3.1-fold (0.49 log units) below what was measured; the whole stated range lies below it.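

In this assay, placing 2-chloro-5-(trifluoromethyl)phenyl in place of 4-chloro-3-(trifluoromethyl)phenyl on the amide-type nitrogen gives a 2.9-fold higher number from compound 2 to compound 4 (0.47 log units; beyond the scatter). The change therefore does not carry over with the same size between the two cores: the same change on two cores in this assay, a 1.1-fold lower number (0.03 log units; within the scatter) from compound 3 to compound 1 and a 2.9-fold higher number (0.47 log units; beyond the scatter) from compound 2 to compound 4, 3.2-fold (0.50 log units) apart, beyond the scatter of two such steps

This rests on a single pair for each core, so it shows that the step depended on the core in these four compounds, but it gives neither a cause nor a rule for any further core. The compounds shown leave open whether the same dependence on the core would appear with a nitrile, an amine or a carboxylic acid in place of the trifluoromethyl group.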